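The source may report more compounds than this note shows. Statements on the series, on what has been measured and on what is new or still open speak of the compounds shown alone.

Three compounds have been measured in a functional assay on DU-145 cells (Homo sapiens) for inhibition, read by trypan blue exclusion, with a stated time of 96 h; a lower number here means a stronger inhibitor of growth, a higher number a weaker inhibitor of growth:

Compound 1 `O=C(/C(=C/c1ccc(Br)cc1)S(=O)(=O)Cc1ccc(I)cc1)c1ccc(I)cc1` — 20000 nM
Compound 2 `O=C(/C(=C\c1cc(Cl)c(O)c(Cl)c1)S(=O)(=O)Cc1ccc(Br)cc1)c1ccc(Br)cc1` — 25000 nM
Compound 3 `COc1cc(OC)c(/C=C(/SCc2ccc(F)cc2)C(=O)c2ccc(Cl)cc2)c(OC)c1` — 10000 nM

Among these three numbers compound 1 holds the second highest, but the gaps to its neighbours are small: compound 2 stands nearest to it and compound 3 furthest, and both separations lie within the usual scatter of this assay. The three numbers therefore cannot be ranked against one another with any confidence.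

Compound 4 `O=C(/C(=C/c1ccc(I)cc1)S(=O)(=O)Cc1ccc(I)cc1)c1ccc(I)cc1` is not yet measured. It differs from compound 1 in one place only: iodo in place of bromo on an aromatic carbon. Among the measured compounds shown here, no pair of measured compounds shows this kind of exchange, so there is no measured step to draw on. Given that the three measured compounds differ widely in their substituents yet sit within the scatter of one another, the step of a 1.1-fold lower number from compound 1 to compound 4 (0.05 log units; within the scatter) is expected to be none beyond the scatter. Compound 4 is accordingly estimated at 18000 nM, with a range from 8000 nM to 40000 nM.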

Compound 4, concentration for 50% growth inhibition: 50000 nM
Beside the measured number, compound 4's estimate is 2.8-fold (0.44 log units) below it, outside the stated range (above it).
By their numbers in this assay, from the lowest: compounds 3, 1, 2 and 4 (each within the scatter of the next, the first and the last beyond it).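

In this assay, among the compounds shown here, the exchange of 4-bromophenyl for 4-iodophenyl gives the first comparison of compounds that differ in one place only, and it is a 2.5-fold higher number from compound 1 to compound 4 (0.40 log units; beyond the scatter) with the iodo group in the compound on the higher side. The earlier compounds shown here differ in several places at once and could not isolate any single group, whereas this modest step shows that the halogen on this aromatic carbon, para to a large group, can alter the number even though the rest of the structure stays the same. No measurement at hand accounts for this step.

On these data alone, this result rests on a single pair, so it remains open whether the same exchange would give a similar step on the other aromatic rings of the shared core. As far as these compounds go, it is also open how an amine or a carboxylic acid in place of the bromo of compound 1 would compare.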